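A few compounds are considered here, and "the series" means these few. Any claim that something is new, unique, unknown or untested is made for them only; others in the source may bear on it.

Compound 1 `Fc1ccc(NC(=S)Nc2nc3ccc(F)cc3s2)cc1` gives 47700 nM in a functional assay on B16-F10 cells (Mus musculus) for cytotoxicity, read by MTT assay, with a stated time of 48 h; on this read-out lower numbers stand for stronger inhibition and higher numbers for weaker inhibition.
Compound 2 `Cc1ccc2nc(NC(=S)Nc3ccccc3)sc2c1` in this assay gives only a limit of the assay, > 50000 nM.
Compound 3 `CCOc1ccc2nc(NC(=S)Nc3ccccc3)sc2c1` in this assay also gives only a limit of the assay, > 50000 nM.

Compound 3 therefore stands at the edge of what this assay can report: its value is not a number but a limit, and it shares this with one further value shown, (the limit of > 50000 nM in this assay, at which 2 of the 3 values shown sit). Going by the values given here, the one measured step that touches this position, a step that the two limits leave unreadable from compound 2 to compound 3, cannot be read in size because both of its ends sit at the limit of > 50000 nM in this assay, at which 2 of the 3 values shown sit.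

Compound 4 `Fc1ccc2nc(NC(=S)Nc3ccccc3)sc2c1` differs from compound 3 in a single place: fluoro in place of ethoxy on an aromatic carbon. Among the compounds with values here, no measured step covers this exchange directly. Within the data shown here, the only readable number among the three, that of compound 1 with 47700 nM in this assay, comes from a compound that also carries fluoro on its fused ring system, though with a different partner ring, so it is a hint and not a step.

Given that compound 3 sits at a limit and the neighbouring step is unreadable, no shift beyond the scatter is expected in this assay; the step of a number no higher from compound 3 to compound 4 (the limit leaves the size open) is an estimate of essentially no change. Compound 4 is therefore expected to give about 50000 nM, within a range of 25000 nM to 100000 nM.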

Compound 4, half-maximal inhibitory concentration: > 50000 nM
Compound 4 was reported as a limit (the forecaster's own chance of this, stated with the estimate: 65%); the middle value lies on the limit itself.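

With fluoro in place of ethoxy, this position has now carried methyl, ethoxy and fluoro, and each of the three compounds ends at the same limit of the assay, so none of these groups has yet produced a readable number here: the limit of > 50000 nM in this assay, at which 3 of the 4 values shown sit.

The steps linking these three compounds have a limit at both ends, and their size cannot be read. Going by these compounds alone, the one step with a readable floor, for hydrogen in place of fluoro on an aromatic carbon, is an at least 1.0-fold higher number from compound 1 to compound 4 (0.02 log units; that floor lies within the scatter), so taking away that fluoro shows no change that can be told from the scatter, though a larger change is not ruled out.

From the compounds shown here alone, whether an amine or a carboxylic acid at this position would give a number within the range of this assay remains open. Going by these compounds, the true size of any differences among the compounds that sit at the limit also remains open.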